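This account rests on a few compounds, and the source may have more. Where it says the series, first, only, none or still open, it means among the compounds named here.

Working notes on the series. In a functional assay on CHOK cells for antagonist activity at growth hormone secretagogue receptor type 1 (Homo sapiens), read by calcium flux (a lower number here means a stronger inhibitor, a higher number a weaker inhibitor), compound 1 `Nc1nc(N)c(-c2ccc(NCc3cc(F)c(S(=O)(=O)C(F)(F)F)c(F)c3)cc2)c(COCc2ccccc2)n1` gives 85 nM, and compound 2 `N#Cc1ccc(CNc2ccc(-c3c(N)nc(N)nc3COCc3ccccc3)cc2)cc1` gives 19 nM. Compound 2 has the lowest number of the two, and its step to compound 1 lies beyond the scatter. Compound 3 `N#Cc1ccc(COc2ccc(-c3c(N)nc(N)nc3COCc3ccccc3)cc2)cc1` carries the change ((4-cyanobenzyl)oxy in place of (4-cyanobenzyl)amino on an aromatic carbon), at the same place, para to a large group. For the measured compounds named here, no measured pair shows this swap, so the step is expected from the structural change alone: a modest rise in the number, at the edge of the scatter, as a step of a 2.1-fold higher number from compound 2 to compound 3 (0.32 log units; beyond the scatter). For compound 3 the estimate in this assay is 40 nM, within 12 nM to 130 nM.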

Compound 3, half-maximal inhibitory concentration: 3610 nM
Beside the measured number, compound 3's estimate is 90-fold (1.96 log units) below it; the whole stated range lies below it.
By their numbers in this assay, from the lowest: compound 2; then compound 1; then compound 3.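

In this assay, for the compounds shown here, the single atom joining the benzyl group to the aromatic carbon, para to a large group, matters far more than the earlier compounds could show: (4-cyanobenzyl)oxy in place of (4-cyanobenzyl)amino gives a 190-fold higher number from compound 2 to compound 3 (2.28 log units; beyond the scatter). The (4-cyanobenzyl)amino group has a hydrogen-bond donor that the (4-cyanobenzyl)oxy group lacks, while their heavy-atom and acceptor counts match. Nothing available ties this step to that donor or to any other feature. Going by these compounds, whether a methylamino or methylene link would track compound 2 or compound 3 remains open. So does the size of this swap with the benzyl group of compound 1.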